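Amine Methylation Carried From One Core to Another

The compounds below may be only part of what the source reports. "The series", "measured", "known", "first", "only" and "open" are said of these compounds alone.

compound 1 `CC1(CN)CCN(c2c(F)cc3c(=O)c(C(=O)O)cn(C4CC4)c3c2Cl)C1`: 8 ug/mL
compound 2 `CC1(CN)CCN(c2nc3c(cc2F)c(=O)c(C(=O)O)cn3C2CC2)C1`: 25 ug/mL
compound 3 `CNCC1(C)CCN(c2c(F)cc3c(=O)c(C(=O)O)cn(C4CC4)c3c2Cl)C1`: 23 ug/mL

Of the compounds shown here, three have been measured in a functional assay on V79 cells (Cricetulus griseus) for cytotoxicity, read by colony formation; a lower number here means a stronger inhibitor, a higher number a weaker inhibitor. Compound 1 gives 8 ug/mL, compound 2 gives 25 ug/mL and compound 3 gives 23 ug/mL. Compound 3 differs from compound 1 only by methyl in place of hydrogen on an amine nitrogen, and this single change produced a 2.9-fold higher number from compound 1 to compound 3 (0.46 log units; beyond the scatter). Compound 2 carries a different core; the difference between the two cores is not broken down here, since compound 2 and compound 1 differ in more than one place. In this assay compound 2 and compound 3 give numbers that lie within the scatter of each other, so no order between them can be read.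

Compound 4 `CNCC1(C)CCN(c2nc3c(cc2F)c(=O)c(C(=O)O)cn3C2CC2)C1` has not yet been measured. It differs from compound 2 by methyl in place of hydrogen on an amine nitrogen, at a place described in the same words as for the pair of compound 1 and compound 3, so it is the same change on the core of compound 2. Carrying the earlier step across, compound 4 is expected to show a 2.2-fold higher number from compound 2 to compound 4 (0.34 log units; beyond the scatter), an expectation resting on a 2.9-fold higher number from compound 1 to compound 3 (0.46 log units; beyond the scatter) and on the starting number of compound 2, 25 ug/mL. The estimated value for compound 4 is therefore 55 ug/mL, expected to fall between 25 ug/mL and 120 ug/mL.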

Compound 4, half-maximal inhibitory concentration: 58 ug/mL
The estimate for compound 4 lay 1.1-fold (0.02 log units) below the measured number; the range from low to high includes it.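

In this assay, methyl in place of hydrogen on the amine nitrogen gave a 2.3-fold higher number from compound 2 to compound 4 (0.37 log units; beyond the scatter), and the same change on the other core runs in the same direction, with no difference in size that can be read: the same change on two cores in this assay, a 2.9-fold higher number (0.46 log units; beyond the scatter) from compound 1 to compound 3 and a 2.3-fold higher number (0.37 log units; beyond the scatter) from compound 2 to compound 4, 1.2-fold (0.09 log units) apart, within the scatter of two such steps. Within these four compounds, then, the change from aminomethyl to (methylamino)methyl carried from the core of compound 1 to the core of compound 2 and kept its direction and size. Within the data shown here, this rests on only two pairs in a single assay, so it does not show that the step would hold on any further core, and it gives no reason for the higher number on either one.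

The compounds shown leave open what an ethyl group or a second methyl on that nitrogen would do to the number. They also leave open whether the step would survive with a longer chain in place of aminomethyl.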